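The source may hold more compounds than are shown below. What is called first, only, known or untested is meant among the compounds shown, and "the series" means these compounds.

Compound 1, `CCc1nc(-c2ccc(OC)cc2)c(C(=O)N2CCN(c3cccc(Cl)c3)CC2)o1`: in a functional assay on HL-60 cells (Homo sapiens) for inhibition, read by MTT assay, with a stated time of 72 h (on this read-out lower numbers stand for stronger inhibition and higher numbers for weaker inhibition), compound 1 gives > 1000 nM, which is a limit of the assay rather than a number.
Compound 2, `COc1cc(OC)cc(N2CCN(C(=O)c3oc(C)nc3-c3cccc(F)c3)CC2)c1`: in this assay compound 2 gives 28.2 nM.
Compound 3, `Cc1ccc(C)c(N2CCN(C(=O)c3oc(C)nc3-c3ccc(Cl)cc3)CC2)c1`: in this assay compound 3 is reported as "not active" (no number reported), with no number given.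

Among these three, only compound 2 has a measured number. Compound 3 stands without one, and of the remaining values one sits at the limit of > 1000 nM in this assay, at which 1 of the 3 values shown sits. Compound 4, `Cc1ccc(C)c(N2CCN(C(=O)c3oc(C)nc3-c3cccc(F)c3)CC2)c1`, has not yet been measured. It differs from compound 3 in one place: 3-fluorophenyl in place of 4-chlorophenyl on an aromatic carbon. For the measured compounds named here, no measured pair of compounds differs in only this way, so no size for this step is known. Since compound 3 carries no number, no direction can be read from its own result. The 3-fluorophenyl group is also present in compound 2, whose value in this assay is 28.2 nM, but compound 2 differs from compound 4 elsewhere as well, so that figure is only a loose guide. With this in mind, compound 4 is expected to give about 300 nM, with a likely range from 30 nM to 3000 nM.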

Compound 4, half-maximal inhibitory concentration: 204 nM
Compound 4: middle estimate off by 1.5-fold (0.17 log units), on the high side; the measured number falls inside the stated range.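

In this assay compound 4 gives a number, while compound 3, with 4-chlorophenyl on the same aromatic carbon of the five-membered aromatic ring, is reported as not active, so measurable inhibition is possible here alongside 2,5-dimethylphenyl. The size of this change cannot be read, since compound 3 has no number. The group on the amine nitrogen in the ring also counts: with 3-fluorophenyl kept, 2,5-dimethylphenyl in place of 3,5-dimethoxyphenyl gives a 7.2-fold higher number from compound 2 to compound 4 (0.86 log units; beyond the scatter).

As far as these compounds go, whether the halogen or its place on the phenyl ring separates compound 3 from compound 4 stays open, and so does how a 4-fluorophenyl or an unsubstituted phenyl would behave on this carbon. Compound 1 does not settle this, as it differs in several places and its value is a limit: the limit of > 1000 nM in this assay, at which 1 of the 4 values shown sits.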